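The source may hold more compounds than are shown below. What is called first, only, known or untested is meant among the compounds shown, and "the series" means these compounds.

Compound 1 `O=C1/C(=C/c2cccc([N+](=O)[O-])c2)S/C(=N\c2ccccc2)N1Cc1ccco1`: "not determined" (no result reported)
Compound 2 `O=C1/C(=C/c2ccc(O)cc2)S/C(=N\c2ccccc2)N1Cc1ccco1`: 400000 nM
Compound 3 `CCOc1ccc(/C=C2\S/C(=N\c3ccccc3)N(Cc3ccco3)C2=O)cc1`: "not determined" (no result reported)

All three compounds share one core and differ only in the aryl group on the double-bonded chain carbon. In a toxicity assay on CHO cells (Cricetulus griseus) for cytotoxicity, read by MTT assay, with a stated time of 48 h (on this read-out lower numbers stand for stronger inhibition and higher numbers for weaker inhibition), compound 3 stands at "not determined" (no result reported), so it has no place on the numerical scale. Compound 1 has no number either, which leaves compound 2 as the single numerical reference point for the series.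

The next structure is compound 4 `O=C1/C(=C/c2ccccn2)S/C(=N\c2ccccc2)N1Cc1ccco1`. The change is pyridin-2-yl in place of 4-ethoxyphenyl on a double-bonded chain carbon bound to a double-bonded ring carbon.

Within the data shown here, no measured step shows what a swap at this place does, and compound 3 offers no starting number. The expectation is therefore modest: no step beyond the usual scatter and no firm direction, with compound 4 expected to land near compound 2 at 400000 nM in this assay. This rests on one value only, so the range is kept wide.

For compound 4 the estimated value is 300000 nM, with an expected range from 90000 nM to 800000 nM.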

Compound 4, half-maximal inhibitory concentration: > 400000 nM
Compound 4 ended at the assay's limit (the forecaster's own chance of this, stated with the estimate: 25%); middle value at least 1.3-fold (0.12 log units) from the limit.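

In this assay compound 4 gives > 400000 nM, which is a limit of the assay and not a number. When pyridin-2-yl replaces the 4-hydroxyphenyl group on the double-bonded chain carbon, the series shows a number no lower from compound 2 to compound 4 (the limit leaves the size open), so this position now has its first comparison, and a ring with a hetero atom there gives no stronger inhibition than the 4-hydroxyphenyl group did. That comparison stops at the edge of the scale, so it gives a direction and no size: the limit of > 400000 nM in this assay, at which 1 of the 4 values shown sits.

Going by these compounds, how far compound 4 lies past its limit stays open, and steps that involve compound 1 or compound 3 cannot be read. On these data alone, it also stays open whether an aminophenyl group, a carboxyphenyl group or a longer chain on this same carbon would give a reading well inside the scale of this assay, and so show whether this position can move the read-out toward stronger inhibition at all.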